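The compounds below may be only part of what the source reports. "The series", "measured", "known", "first", "only" and "open" are said of these compounds alone.

Of the compounds shown here, three built on one shared core have been tested in an assay on CHO cells for displacement of a labelled ligand from adenosine receptor A3 (Homo sapiens), read by scintillation counting, tested at 10 uM; a lower number here means less inhibition, a higher number more inhibition at the concentration tested (going by the name of the read-out). Compound 1 `COc1ccccc1-c1sc(N)c(C(=O)c2ccc(Cl)cc2)c1CC(C)(C)C` gives 1% in this assay, compound 2 `COCCOc1ccc(-c2sc(N)c(C(=O)c3ccc(Cl)cc3)c2CC(C)(C)C)cc1` gives 1%, and compound 3 `Cc1cccc(-c2sc(N)c(C(=O)c3ccc(Cl)cc3)c2CC(C)(C)C)c1` gives 1%. Compound 3 therefore stands level with compounds 1 and 2 at the digits shown: the one measured step that changes a single place, no change at the digits printed from compound 1 to compound 3 (within the scatter), is within the scatter, and the two values of compounds 2 and 3 are likewise indistinguishable from each other.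

Compound 4 `CC(C)c1ccc(-c2sc(N)c(C(=O)c3ccc(Cl)cc3)c2CC(C)(C)C)cc1` has not yet been measured. It differs from compound 3 in one place: 4-isopropylphenyl in place of 3-methylphenyl on an aromatic carbon. Within the data shown here, the only measured step that touches this same place, no change at the digits printed from compound 1 to compound 3 (within the scatter), exchanged one aromatic ring for another without moving the read-out beyond the scatter. On that evidence the exchange for a 4-isopropylphenyl group is expected to behave the same way, so a number 1 percentage points higher from compound 3 to compound 4 (within the scatter) is estimated to be no step beyond the scatter. Compound 4 is accordingly expected to give about 2% in this assay, with a range from -8% to 12%.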

Compound 4, a percentage reported as inhibition, at one concentration (the size of the read-out at that concentration, not a potency): 1%
Beside the measured number, compound 4's estimate is 1 percentage points above it; the range from low to high includes it.
By their numbers in this assay, from the lowest: compounds 1, 2, 3 and 4 (each within the scatter of the next).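

In this assay, replacing 3-methylphenyl with the bulkier-by-count 4-isopropylphenyl, 9 heavy atoms against 7, gives no change at the digits printed from compound 3 to compound 4 (within the scatter), so adding carbon to this aryl group and placing it differently on the ring leaves the read-out unmoved. The comparisons with the two oxygen-bearing compounds agree: exchanging 2-methoxyphenyl for 4-isopropylphenyl gives no change at the digits printed from compound 1 to compound 4 (within the scatter), and putting isopropyl in place of 2-methoxyethoxy gives no change at the digits printed from compound 2 to compound 4 (within the scatter), so an all-carbon substituent and an ether-containing one cannot be told apart in these compounds. Nothing shown here offers an explanation for this flat result.

All of these readings lie together at a very low level, so they do not reveal whether any change at this place could raise the inhibition, and they cannot rank the groups tested. From the compounds shown here alone, a phenyl ring carrying a carboxylic acid or an amine at this place remains open, as does the effect of replacing the neopentyl group or the (4-chlorophenyl)carbonyl group elsewhere on the shared core.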